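Swapping the pyridine for a fluorophenyl on the piperazine

This account rests on a few compounds, and the source may have more. Where it says the series, first, only, none or still open, it means among the compounds named here.

Of the compounds shown here, three sharing one core have been tested in a functional assay on HEK293 cells for agonist activity at Free fatty acid receptor 1 (Homo sapiens), read by fluorescence and calcium flux; on this read-out higher numbers stand for an effect only at larger amounts of compound and lower numbers for an effect already at smaller amounts. Compound 1 `CC#CC(CC(=O)O)c1ccc(OCc2ccc(C(=O)N3CCN(c4cccnc4)CC3)s2)cc1` gives 1140 nM. Compound 2 `CC#CC(CC(=O)O)c1ccc(OCc2ccc(C(=O)N3CCN(c4ccccn4)CC3)s2)cc1` gives 138 nM, the lowest of the three numbers. Compound 3 `CC#CC(CC(=O)O)c1ccc(OCc2ccc(C(=O)N3CCN(c4ccc(C(C)(C)C)cc4)CC3)s2)cc1` gives 417 nM. The measured steps are an 8.3-fold lower number from compound 1 to compound 2 (0.92 log units; beyond the scatter), a 2.7-fold lower number from compound 1 to compound 3 (0.44 log units; beyond the scatter) and a 3.0-fold higher number from compound 2 to compound 3 (0.48 log units; beyond the scatter), so compound 2 stands out as the one that acts at the smallest amounts here.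

Compound 4 `CC#CC(CC(=O)O)c1ccc(OCc2ccc(C(=O)N3CCN(c4ccccc4F)CC3)s2)cc1` differs from compound 2 in one place: 2-fluorophenyl in place of pyridin-2-yl on an amine nitrogen in a ring. Going by the values given here, no measured step involves a 2-fluorophenyl group, so the only guidance is indirect. The step from compound 2 to compound 3 shows that replacing the pyridin-2-yl group by a ring of carbon only cost potency, and the step from compound 1 to compound 2 shows that the pyridin-2-yl arrangement was itself favourable. A modest loss is therefore expected for compound 4, of about a 2.5-fold higher number from compound 2 to compound 4 (0.40 log units; beyond the scatter). Compound 4 is estimated to give 350 nM, within a range from 120 nM to 1000 nM.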

Compound 4, half-maximal effective concentration: 113 nM
Beside the measured number, compound 4's estimate is 3.1-fold (0.49 log units) above it, and the stated range ends above it.
By their numbers in this assay, from the lowest: compounds 4 and 2 (each within the scatter of the next); then compound 3; then compound 1.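

In this assay, a ring of carbon only can serve on this amine nitrogen as well as pyridin-2-yl: the change to 2-fluorophenyl gives a 1.2-fold lower number from compound 2 to compound 4 (0.09 log units; within the scatter), so the hydrogen-bond acceptor counted on pyridin-2-yl is not needed to reach this level. The identity of the group still matters, as the replacement of 4-(tert-butyl)phenyl by 2-fluorophenyl gives a 3.7-fold lower number from compound 3 to compound 4 (0.57 log units; beyond the scatter), and the replacement of pyridin-3-yl by 2-fluorophenyl gives a 10-fold lower number from compound 1 to compound 4 (1.00 log units; beyond the scatter). No measurement available here accounts for these differences.

The compounds shown leave open what a plain phenyl group would give on this nitrogen, so the contribution of the fluorine cannot be separated from that of the ring. Also open, going by these compounds, is how 2-chlorophenyl or 2-methoxyphenyl would compare with 2-fluorophenyl.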